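This account rests on a few compounds, and the source may have more. Where it says the series, first, only, none or still open, it means among the compounds named here.

Compound 1 `CCCc1cc(NNC(=O)Nc2cc(Cl)nc(Cl)c2)nc2c1c(C)nn2C`: 40800 nM
Compound 2 `Cc1nn(C)c2nc(NNC(=O)Nc3cc(Cl)nc(Cl)c3)cc(-c3ccco3)c12`: > 100000 nM (a limit)

In a functional assay on SW620/5-FU cells (Homo sapiens) for cytotoxicity, read by MTT assay, with a stated time of 48 h, in the presence of a further agent that is not named here (on this read-out higher numbers stand for an effect only at larger amounts of compound and lower numbers for an effect already at smaller amounts), compound 2 stands only at a limit of > 100000 nM, not at a number. Compound 3 `Cc1nn(C)c2nc(NNC(=O)Nc3cc(Cl)nc(Cl)c3)cc(C3CCCCC3)c12` brings the change (cyclohexyl in place of furan-2-yl on an aromatic carbon), with cyclohexyl in place of furan-2-yl on an aromatic carbon. Among the compounds with values here, one measured step bears on this: an at least 2.4-fold higher number from compound 1 to compound 2 (0.38 log units; beyond the scatter), where furan-2-yl replaced propyl. Cyclohexyl, like propyl, is carbon only, so a move back toward compound 1 at 40800 nM is expected, of at least modest size and to a lower number. The expected step is an at least 2.0-fold lower number from compound 2 to compound 3 (0.30 log units; that floor lies within the scatter). For compound 3 the estimate is 50000 nM, with an expected range of 15000 nM to 100000 nM.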

Compound 3, half-maximal effective concentration: 22000 nM
Compound 3: the middle estimate sits 2.3-fold (0.36 log units) above what was measured; the measured number falls inside the stated range.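

Cyclohexyl in place of furan-2-yl, on the aromatic carbon opposite the ring nitrogen, gives an at least 4.5-fold lower number from compound 2 to compound 3 (0.65 log units; beyond the scatter) in this assay. The value of compound 2 is a limit, > 100000 nM, so this step has only a floor. Cyclohexyl in place of propyl gives a 1.9-fold lower number from compound 1 to compound 3 (0.27 log units; within the scatter), so this read-out does not tell these two carbon-only groups apart, chain or ring.

The compounds shown do not separate the ring oxygen of furan-2-yl from its aromatic ring, a question a phenyl ring here would bear on. On these data alone, how an amine or a longer chain at this position would read also stays open.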